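A few compounds are considered here, and "the series" means these few. Any claim that something is new, unique, unknown or untested is made for them only; others in the source may bear on it.

Working notes on the series. Three compounds share one core and differ only in the amine end of the chain on the ring nitrogen. Compound 1 `Cc1cc(-c2ccccc2)nnc1NCCCN` gives 0.1 mg/kg in a functional assay on the whole organism with Mus musculus as the target; on this read-out higher numbers stand for an effect only at larger amounts of compound and lower numbers for an effect already at smaller amounts. Compound 2 `CCCN(CCC)CCNc1nnc(-c2ccccc2)cc1C` gives 2 mg/kg. Compound 3 `Cc1cc(-c2ccccc2)nnc1NCCN` gives 0.5 mg/kg; it stands second highest of the three, with a 5.0-fold higher number from compound 1 to compound 3 (0.70 log units; beyond the scatter) and a 4.0-fold lower number from compound 2 to compound 3 (0.60 log units; beyond the scatter) placing it between the other two. The step to compound 4 `Cc1cc(-c2ccccc2)nnc1NCCN(C)C` is dimethylamino in place of amino on a saturated chain carbon, two bonds along the chain from a nitrogen on an aromatic ring. The step that bears on it most directly is a 4.0-fold lower number from compound 2 to compound 3 (0.60 log units; beyond the scatter), where exchanging a larger dialkylamino for the free amino lowered the number; the new change runs the other way, toward a dialkylamino, but a smaller one than in compound 2. A rise in the number is therefore expected for compound 4, smaller than that seen with compound 2 and near the edge of the scatter, so that a 2.0-fold higher number from compound 3 to compound 4 (0.30 log units; within the scatter) is the estimated step. Compound 4 is expected at 1 mg/kg, with a range from 0.4 mg/kg to 3 mg/kg.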

Compound 4, minimum effective dose: 10 mg/kg
Compound 4: middle estimate off by 10-fold (1.00 log units), on the low side, and the stated range ends below it.
By their numbers in this assay, from the lowest: compound 1; then compound 3; then compound 2; then compound 4.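

In this assay, dimethylamino in place of amino at this saturated chain carbon is a large change (a 20-fold higher number from compound 3 to compound 4 (1.30 log units; beyond the scatter)), so a small dialkylamino is not tolerated here as a mild variation on the free amine. Nor does the number rise with the size of the alkyl groups on this nitrogen, since compound 2, with dipropylamino, goes against that trend (a 5.0-fold higher number from compound 2 to compound 4 (0.70 log units; beyond the scatter)), and the full spread now reaches (a 100-fold higher number from compound 1 to compound 4 (2.00 log units; beyond the scatter)) across the amine ends shown. Nothing at hand explains this order.

Methylamino and diethylamino on the same chain would show whether the rise appears with a single methyl and whether it falls steadily from dimethylamino to dipropylamino. A 3-(dimethylamino)propyl chain would show whether the longer chain of compound 1 keeps its low number once its amine carries two methyl groups.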